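From 2-fluorobenzyl to 3-chloro-2-fluorobenzyl: compound 3 to compound 4

The compounds below may be only part of what the source reports. "The series", "measured", "known", "first", "only" and "open" are said of these compounds alone.

In an ADME assay on C8166 cells (Homo sapiens) for cytotoxicity, read by MTT assay (a higher number here means that more compound is tolerated, a lower number that less compound is tolerated), compound 1 (`CC(C)[C@@H](CO)n1cc(C(=O)O)c(=O)c2c(O)c(Cc3cccc(Cl)c3F)ccc21`) gives 125000 nM and compound 2 (`Cc1ccc(-n2cc(C(=O)O)c(=O)c3c(O)c(Cc4cccc(Cl)c4F)ccc32)cc1`) gives 194000 nM. Compound 3 (`O=C(O)c1cn(Cc2ccccc2)c2ccc(Cc3ccccc3F)c(O)c2c1=O`) gives 156000 nM, within the scatter of both compound 1 and compound 2, so the three numbers show no order among them.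

Compound 4 (`O=C(O)c1cn(Cc2ccccc2)c2ccc(Cc3cccc(Cl)c3F)c(O)c2c1=O`) differs from compound 3 in one place: chloro in place of hydrogen on an aromatic carbon. This is chloro in place of hydrogen on an aromatic carbon, ortho to a fluoro group, and it turns 2-fluorobenzyl into 3-chloro-2-fluorobenzyl.

Among the measured compounds shown here, no measured step isolates this change. For the measured compounds named here, the only step available, a 1.6-fold higher number from compound 1 to compound 2 (0.19 log units; within the scatter), concerns the group on the aromatic nitrogen and bears on the question only indirectly. More useful is the comparison of values: compound 1 and compound 2 already carry the 3-chloro-2-fluorobenzyl group, yet neither separates from compound 3 at 156000 nM beyond the scatter. These compounds also differ from compound 3 on the aromatic nitrogen, so the comparison is not a clean one.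

No step beyond the scatter is therefore expected in this assay. The estimated change is a 1.0-fold lower number from compound 3 to compound 4 (0.02 log units; within the scatter). Compound 4 is expected at 150000 nM, with an estimated range from 75000 nM to 300000 nM.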

Compound 4, half-maximal cytotoxic concentration: 20300 nM
Compound 4: middle estimate off by 7.4-fold (0.87 log units), on the high side; the measured number lies below the stated range.
By their numbers in this assay, from the lowest: compound 4; then compounds 1, 3 and 2 (each within the scatter of the next).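

In this assay, chloro in place of hydrogen on an aromatic carbon, ortho to a fluoro group, is not silent when the aromatic nitrogen carries benzyl: the change gives a 7.7-fold lower number from compound 3 to compound 4 (0.89 log units; beyond the scatter). The group on the aromatic nitrogen also counts once 3-chloro-2-fluorobenzyl is present, with benzyl giving a 9.6-fold lower number from compound 2 to compound 4 (0.98 log units; beyond the scatter) in place of 4-methylphenyl and a 6.2-fold lower number from compound 1 to compound 4 (0.79 log units; beyond the scatter) in place of 1-(hydroxymethyl)-2-methylpropyl, so among these four compounds the lower number appears only where benzyl and chloro occur together. No measurement at hand accounts for these steps.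

Whether the chloro step depends on benzyl stays open, since the 2-fluorobenzyl group is shown only with benzyl on the aromatic nitrogen, and a partner of compound 1 or compound 2 carrying 2-fluorobenzyl would settle it. Also open, going by these compounds, is whether the step belongs to chloro itself or would recur with bromo, methyl or an amine on the same aromatic carbon.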